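A few compounds are considered here, and "the series" means these few. Any claim that something is new, unique, unknown or untested is made for them only; others in the source may bear on it.

Compound 1, `CCOc1cc(=O)n(CCCO)c2c1CC(CC=C(C)C)C(C)(C)C2`: 16.6%
Compound 2, `CCOc1cc(=O)n(CCCO)c2c1CC(C/C=C(\C)CCC=C(C)C)C(C)(C)C2`: 0.8%

In a functional assay on PANC-1 cells (Homo sapiens) for inhibition, read by MTT assay, with a stated time of 24 h, tested at 10 uM (on this read-out higher numbers stand for more inhibition at the one concentration tested (going by the name of the read-out) and lower numbers for less inhibition), compound 1 gives 16.6%, while compound 2 gives 0.8%. Going by the values given here, compound 2 thus stands lowest of the two numbers, and the only measured step is a number 15.8 percentage points lower from compound 1 to compound 2 (beyond the scatter), a modest fall that lies beyond the scatter.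

Compound 3, `CC(C)=CCC/C(C)=C/CC1Cc2c(OCCCNC(=O)c3ccco3)cc(=O)n(CCCO)c2CC1(C)C`, differs from compound 2 by (((furan-2-yl)carbonyl)amino)methyl in place of hydrogen on a saturated chain carbon, two bonds along the chain from an oxygen on an aromatic ring. Among the compounds with values here, no measured step touches this part of the structure; the one step that exists concerns a different place, so it gives no direct guide to what this change will do. The expectation therefore rests on the starting value of compound 2, which is already near the bottom of the scale. For compound 3 the expected step is a number 5.2 percentage points higher from compound 2 to compound 3 (within the scatter), that is, none beyond the scatter. Compound 3 is accordingly estimated at 6%, with a range from 0% to 25%.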

Compound 3, a percentage reported as inhibition, at one concentration (the size of the read-out at that concentration, not a potency): 2.8%
The estimate for compound 3 lay 3.2 percentage points above the measured number, and the stated range covers the measured number.
By their numbers in this assay, from the lowest: compounds 2 and 3 (each within the scatter of the next); then compound 1.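

In this assay, the change from ethoxy to 3-(((furan-2-yl)carbonyl)amino)propoxy gives a number 2 percentage points higher from compound 2 to compound 3 (within the scatter), so this position accepts the added 9 heavy atoms, with their five-membered aromatic ring, without a reading beyond the scatter. Going by these compounds alone, compound 2 already gives 0.8%, however, so the step shows only that the change brings no gain beyond the scatter on this background; a further loss would have little room to appear near the bottom of the scale. Nothing available explains this outcome.

Going by these compounds, it remains open whether the same change would behave alike on the core of compound 1, whose reading leaves more room for a fall. Also open, on these data alone, is whether a free amine or a carboxylic acid at the end of a propoxy chain, or a longer chain carrying the furan amide, would move the reading.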